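The compounds below may be only part of what the source reports. "The series", "measured", "known", "first", "only" and "open" are said of these compounds alone.

In a functional assay on HCT-116 cells (Homo sapiens), read by MTT assay, with a stated time of 72 h (on this read-out higher numbers stand for weaker inhibition and lower numbers for stronger inhibition), compound 1 `CNc1ncnc2c1c(-c1ccco1)cn2[C@@H]1O[C@H](CO)[C@@H](O)[C@H]1O` gives 230 nM. Compound 2 `CNc1ncnc2c1c(-c1ccoc1)cn2[C@@H]1O[C@H](CO)[C@@H](O)[C@H]1O` has only a limit of the assay, > 20000 nM. Compound 3 `CNc1ncnc2c1c(-c1cccs1)cn2[C@@H]1O[C@H](CO)[C@@H](O)[C@H]1O` also has only a limit, > 20000 nM. This is the limit of > 20000 nM in this assay, at which 2 of the 3 values shown sit. Compound 4 `CNc1ncnc2c1c(-c1ccsc1)cn2[C@@H]1O[C@H](CO)[C@@H](O)[C@H]1O` differs from compound 3 in one place: thiophen-3-yl in place of thiophen-2-yl on an aromatic carbon.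

Going by the values given here, two measured steps bear on this change, and both start from compound 1. Furan-3-yl in place of furan-2-yl gave an at least 86-fold higher number from compound 1 to compound 2 (1.93 log units; beyond the scatter). Thiophen-2-yl in place of furan-2-yl gave an at least 86-fold higher number from compound 1 to compound 3 (1.93 log units; beyond the scatter). Both steps are large, yet between the two compounds that end at the limit there is only a step that the two limits leave unreadable from compound 2 to compound 3. Neither step shows a thiophene with a measurable number, so no gain is expected for compound 4 over compound 3. The expected change is a number no higher from compound 3 to compound 4 (the limit leaves the size open), and no step beyond the scatter is anticipated. For compound 4 the estimated value is 20000 nM, with an expected range from 4000 nM to 40000 nM.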

Compound 4, half-maximal inhibitory concentration: > 20000 nM
Compound 4: only a limit was reported; the forecaster's own chance of this, stated with the estimate: 70%; the middle value lies on the limit itself.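

Compound 4, with thiophen-3-yl, ends at a limit in this assay, as compound 3 with thiophen-2-yl does, so changing the point of attachment on the thiophene gives no measurable number, and the steps to compound 4 from compound 2 and from compound 3 cannot be read. Thiophen-3-yl in place of furan-2-yl gives an at least 86-fold higher number from compound 1 to compound 4 (1.93 log units; beyond the scatter), which leaves compound 1 as the only one of the four with a measured value. The series now sits mostly at one limit: the limit of > 20000 nM in this assay, at which 3 of the 4 values shown sit.

Going by these compounds, how far compound 2, compound 3 and compound 4 lie past that limit stays open, so no order among them can be given. Also open, on these data alone, is how a pyrrol-2-yl group at this place, or a methyl group on the furan-2-yl ring, would read.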